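A few compounds are considered here, and "the series" means these few. Any claim that something is new, unique, unknown or untested is made for them only; others in the source may bear on it.

Compound 1 `CC(O)(CSc1cccc(S(F)(F)(F)(F)F)c1)C(=O)Nc1cccc(S(F)(F)(F)(F)F)c1` and compound 2 `CC(O)(CSc1cccc(OC(F)(F)F)c1)C(=O)Nc1cccc(S(F)(F)(F)(F)F)c1` share one core; compound 3 `CC(O)(COc1ccc(S(F)(F)(F)(F)F)cc1)C(=O)Nc1ccc(S(F)(F)(F)(F)F)cc1` and the as yet unmeasured compound 4 `CC(O)(COc1ccc(OC(F)(F)F)cc1)C(=O)Nc1ccc(S(F)(F)(F)(F)F)cc1` share another. The difference between the two cores is not broken down here.

In a functional assay on DU-145 cells (Homo sapiens) for antiproliferative activity, read by propidium iodide staining, with a stated time of 96 h (a higher number here means a weaker inhibitor, a lower number a stronger inhibitor), compound 1 gives 30300 nM. Compound 2 gives 25000 nM in this assay, and compound 3 gives 24900 nM in this assay. The three values lie within the usual scatter of one another, so no order among them is read.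

The change from compound 1 to compound 2 is a group of 5 heavy atoms (1 carbon, 1 oxygen, 3 fluorine; no ring) in place of a group of 6 heavy atoms (5 fluorine, 1 sulfur; no ring), on an aromatic carbon. It made a 1.2-fold lower number from compound 1 to compound 2 (0.08 log units; within the scatter). Compound 4 carries the same kind of change against compound 3: a group of 5 heavy atoms (1 carbon, 1 oxygen, 3 fluorine; no ring) in place of a group of 6 heavy atoms (5 fluorine, 1 sulfur; no ring), on an aromatic carbon. The two places are not identical: in compound 2 the entering group sits meta to a large group, in compound 4 para to a large group, on a six-membered aromatic ring of carbon only in both.

Because the earlier step of this kind was a 1.2-fold lower number from compound 1 to compound 2 (0.08 log units; within the scatter), a similarly small step is expected here, a 1.1-fold lower number from compound 3 to compound 4 (0.05 log units; within the scatter). Compound 4 is therefore estimated at about 22000 nM in this assay, with a likely range from 11000 nM to 44000 nM.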

Compound 4, half-maximal inhibitory concentration: 24800 nM
The estimate for compound 4 lay 1.1-fold (0.05 log units) below the measured number, and the stated range covers the measured number.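

In this assay, trifluoromethoxy in place of the group of 6 heavy atoms, on an aromatic carbon para to a large group, gave a 1.0-fold lower number from compound 3 to compound 4 (0.00 log units; within the scatter). Set beside the earlier step on the other core, the change reads alike on both: the same change on two cores in this assay, a 1.2-fold lower number (0.08 log units; within the scatter) from compound 1 to compound 2 and a 1.0-fold lower number (0.00 log units; within the scatter) from compound 3 to compound 4, 1.2-fold (0.08 log units) apart, within the scatter of two such steps This shows only that the swap stayed within the scatter on the two cores shown; neither step has a size that could be said to carry over, so it does not show a transferable gain or loss, nor that the same would hold on any further core.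

The compounds shown leave open whether a group of another kind, such as an amine, a carboxylic acid or a nitrile, on that aromatic carbon would move the number beyond the scatter. Also open is how the shared cores themselves compare, since the compounds shown include no pair that isolates their difference in one place.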